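Swapping Isobutyl for Cyclopentyl in Compound 2

A few compounds are considered here, and "the series" means these few. Any claim that something is new, unique, unknown or untested is made for them only; others in the source may bear on it.

Within the data shown here, only two compounds have numbers so far. In a functional assay on HCT-116 cells (Homo sapiens) for antiproliferative activity, read by MTT assay, with a stated time of 72 h (a higher number here means a weaker inhibitor, a lower number a stronger inhibitor), compound 2 `CC(C)CNC(=N)NC(=N)Nc1ccc(F)cc1F` gives 21100 nM, the higher and therefore weaker of the two results. Compound 1 `N=C(NC(=N)NC1CCCC1)Nc1ccc(C(F)(F)F)cc1` gives 3800 nM, and this gap lies beyond the usual scatter of repeated measurements.

Compound 3 `N=C(NC(=N)NC1CCCC1)Nc1ccc(F)cc1F` is still unmeasured. It keeps the rest of compound 2 and changes one group, with cyclopentyl in place of isobutyl on an amine nitrogen.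

Among the measured compounds shown here, no pair of measured compounds shows this swap on its own, so its effect in this assay cannot be read directly from the data. For the measured compounds named here, the only hint is that compound 1, which also carries cyclopentyl, gives 3800 nM. That compound also differs elsewhere, so the hint is weak.

A modest move toward a lower number is therefore expected, close to the limit of the scatter. The estimated change is a 1.9-fold lower number from compound 2 to compound 3 (0.28 log units; within the scatter). For compound 3, the estimate is 11000 nM, with an expected range from 4500 nM to 24000 nM.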

Compound 3, half-maximal inhibitory concentration: 29500 nM
Estimate against measurement, compound 3: 2.7-fold (0.43 log units) below; the measured number lies above the stated range.
By their numbers in this assay, from the lowest: compound 1; then compounds 2 and 3 (each within the scatter of the next).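

In this assay, replacing isobutyl with cyclopentyl on an amine nitrogen gives a 1.4-fold higher number from compound 2 to compound 3 (0.15 log units; within the scatter). Among these compounds, this is the first direct reading of the swap: with the rest of compound 2 held constant, an open branched group and a five-membered non-aromatic ring of carbon only cannot be told apart at this position. The presence of a ring at this nitrogen therefore brings no measurable gain on this core, and no available evidence bears on why the two groups give results within the scatter of each other.

Other kinds of group at this nitrogen remain untested here, so a longer chain such as n-hexyl, a phenyl ring or a chain ending in a hydroxyl group could still move the number beyond the scatter. As far as these compounds go, it also remains open whether isobutyl and cyclopentyl would again fall within the scatter on the rest of compound 1, as only cyclopentyl appears on that part of the series.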